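The source may report more compounds than this note shows. Statements on the series, on what has been measured and on what is new or still open speak of the compounds shown alone.

Of the compounds shown here, two sharing one core have been tested so far in a functional assay on HT-29 cells (Homo sapiens) for antiproliferative activity, read by MTT assay, with a stated time of 24 h; a higher number here means a weaker inhibitor, a lower number a stronger inhibitor. Compound 1 `COc1ccc(C(=O)/C=C/c2ccc([N+](=O)[O-])cc2)c2c1C=CC(C)(C)O2` gives 3730 nM. Compound 2 `COc1ccc(C(=O)/C=C/c2ccsc2)c2c1C=CC(C)(C)O2` gives > 10000 nM, which is a limit of the assay and not a number. Compound 2 therefore stands at the limit of > 10000 nM in this assay, at which 1 of the 2 values shown sits.

The next compound, compound 3 `COc1ccc(C(=O)/C=C/c2ccc(Cl)cc2)c2c1C=CC(C)(C)O2`, changes a single place in compound 2: 4-chlorophenyl in place of thiophen-3-yl on a double-bonded chain carbon bound to a double-bonded chain carbon. Put simply, 4-chlorophenyl takes the place of thiophen-3-yl on a double-bonded chain carbon bound to a double-bonded chain carbon.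

Among the measured compounds shown here, only one measured step bears on this change: an at least 2.6-fold higher number from compound 1 to compound 2 (0.42 log units; beyond the scatter). That step replaced 4-nitrophenyl with thiophen-3-yl at this same place, and the number rose beyond the scatter. Compound 3 brings back a substituted phenyl ring, although with chlorine rather than the nitro group of compound 1 at 3730 nM. A modest move towards a lower number therefore seems likely, landing near compound 1 but with real uncertainty.

The expected change is an at least 2.2-fold lower number from compound 2 to compound 3 (0.34 log units; beyond the scatter), and this estimate starts from a limit. For compound 3 the estimated value is 4500 nM, with an expected range from 1800 nM to 11000 nM.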

Compound 3, half-maximal inhibitory concentration: > 10000 nM
Compound 3: only a limit was reported; the forecaster's own chance of this, stated with the estimate: 25%; at least 2.2-fold (0.34 log units) between middle value and limit.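

Chloro in place of nitro on an aromatic carbon gives an at least 2.6-fold higher number from compound 1 to compound 3 (0.42 log units; beyond the scatter) in this assay. Among the compounds shown here, a phenyl ring at this place is therefore not enough on its own to keep the number where it stands for compound 1, since 4-chlorophenyl gives no readable gain over thiophen-3-yl, and among the three compounds the nitro group is the one change that brings the value under the limit. Compound 2 and compound 3 both rest at a limit of the assay and not at a number, so the step between them cannot be read and the two cannot be ranked: the limit of > 10000 nM in this assay, at which 2 of the 3 values shown sit.

From the compounds shown here alone, how far beyond that limit each of these two compounds lies stays unknown, and a single measured number, that of compound 1, cannot show whether the nitro group itself is needed or whether other groups on the phenyl ring would serve as well. A phenyl ring carrying an amine, a nitrile or a carboxylic acid at this place would help to separate these possibilities.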